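Removing the methoxy group: the step from compound 1 to compound 3

A few compounds are considered here, and "the series" means these few. Any claim that something is new, unique, unknown or untested is made for them only; others in the source may bear on it.

The account follows a pair of benzyl thioimidates that share a common core. Compound 1 `COc1ccc(C(=N)SCc2ccccc2)cc1` was examined in an ADME assay for pharmacokinetics, in phosphate buffer, with a stated time of 30 min, at pH 7.4, tested at 1 mM, at a dose of 1 mM, in the presence of a further agent that is not named here (on this read-out higher numbers stand for higher exposure at the dose given and lower numbers for lower exposure), where compound 1 gives 7200 nM. Among the two numbers shown, compound 1 stands highest, though its nearest companion sits within the usual scatter. For the measured compounds named here, that companion is compound 2 `N=C(SCc1ccccc1)c1cccs1`, which in this assay gives 4600 nM, a reading that cannot be separated from the one for compound 1 with confidence.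

The step under consideration leads to compound 3 `N=C(SCc1ccccc1)c1ccccc1`, which is still to be measured in this assay. Compared with compound 1, the structural difference is this: hydrogen in place of methoxy on an aromatic carbon. Going by the values given here, no measured pair in this set shows what such a change does in this assay, so no size of step can be read off from the data.

Compound 3 is therefore expected to give 6000 nM in this assay, with a range from 3000 nM to 12000 nM. The expected step of a 1.2-fold lower number from compound 1 to compound 3 (0.08 log units; within the scatter) is estimated to lie within the scatter, in no particular direction beyond it.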

Compound 3, maximal plasma concentration in the ADME assay: 3200 nM
Compound 3: the middle estimate sits 1.9-fold (0.27 log units) above what was measured, and the stated range covers the measured number.
By their numbers in the ADME assay, from the lowest: compounds 3, 2 and 1 (each within the scatter of the next, the first and the last beyond it).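

For the compounds shown here, this is the first measured step at this position, and it shows that the methoxy group on the aromatic carbon counts in the ADME assay: hydrogen in its place gives a 2.3-fold lower number from compound 1 to compound 3 (0.35 log units; beyond the scatter). The same change also registers in a second read-out, since in a physicochemical assay for pharmacokinetics, in phosphate buffer, with a stated time of 30 min, at pH 7.4, tested at 1 mM, in the absence of a further agent (a lower number here means that the compound disappears faster, a higher number that the compound lasts longer), compound 1 gives 0.289 h and compound 3 gives 0.0602 h, which is a 4.8-fold lower number from compound 1 to compound 3 (0.68 log units; beyond the scatter). For this single pair, then, the lower exposure and the shorter half-life appear together, although one pair cannot establish that the two read-outs are linked.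

The compounds shown leave open whether the methoxy group itself is needed or whether another group in the same place, such as ethoxy, a longer alkoxy chain, an amine or a chlorine atom, would give similar numbers in both read-outs. They also leave open whether the same change would have a comparable effect on a different core, such as that of compound 2, which has no partner here differing from it in one place.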